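This account rests on a few compounds, and the source may have more. Where it says the series, first, only, none or still open, it means among the compounds named here.

Compound 1 (`CCCCn1ccnc1-c1cc(OC)c(OC)c(OC)c1`) carries a butyl group on an aromatic nitrogen of the shared core. In a functional assay on T47D cells (Homo sapiens) for antiproliferative activity, read by MTT assay, with a stated time of 72 h (a lower number here means a stronger inhibitor, a higher number a weaker inhibitor), compound 1 gives > 100000 nM, which is a limit of the assay and not a number. Compound 1 therefore stands at the limit of > 100000 nM in this assay, at which 1 of the 3 values shown sits.

Two other compounds, each with an aromatic ring on that nitrogen instead of butyl, do return numbers. Compound 2 (`COc1cc(-c2nccn2-c2ccc3sccc3c2)cc(OC)c1OC`) gives 17000 nM and compound 3 (`COc1cc(-c2nccn2-c2cccc([N+](=O)[O-])c2)cc(OC)c1OC`) gives 17900 nM, two values within the usual scatter of each other.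

Compound 4 (`COc1cc(-c2nccn2-c2ccc(F)cc2)cc(OC)c1OC`) has not yet been measured. In it, 4-fluorophenyl stands in place of butyl on an aromatic nitrogen, next to the ring atom that bears a large group (4-fluorophenyl in place of butyl on an aromatic nitrogen).

For the measured compounds named here, no measured step isolates this change, so the expectation in this assay rests on the two aryl compounds, compound 2 at 17000 nM and compound 3 at 17900 nM. A move towards stronger inhibition, beyond the scatter, is therefore expected, landing close to those two values. On these data alone, the expected step is an at least 6.6-fold lower number from compound 1 to compound 4 (0.82 log units; beyond the scatter), and its true size stays open as long as the starting point is only a limit. For compound 4 the estimated value is 15000 nM, with an expected range from 5000 nM to 50000 nM.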

Compound 4, half-maximal inhibitory concentration: > 100000 nM
Compound 4: no number, only a limit (the forecaster's own chance of this, stated with the estimate: 15%); at least 6.6-fold (0.82 log units) between middle value and limit.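

Compound 1 and compound 4 both stand at a limit of the assay and not at a number, so no step from one to the other can be read: the limit of > 100000 nM in this assay, at which 2 of the 4 values shown sit.

The compounds shown leave open how far either lies past that limit, and whether 4-fluorophenyl in place of butyl changes activity at all in this assay.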